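The compounds below may be only part of what the source reports. "The series", "measured", "known", "first", "only" and "open" are said of these compounds alone.

Measured in an assay (strain Holtzman-Sprague-Dawley) for inhibition of 3-hydroxy-3-methylglutaryl-coenzyme A reductase (Rattus norvegicus), with a stated time of 30 min; on this read-out higher numbers stand for weaker inhibition and lower numbers for stronger inhibition:
- compound 1 `COc1cccc(Sc2c(/C=C/[C@@H]3C[C@@H](O)CC(=O)O3)cnc3cc(Cl)c(F)cc23)c1` gives 9240 nM
- compound 2 `COc1cccc(Sc2c(F)cc3c(Sc4cccc(OC)c4)c(/C=C/[C@@H]4C[C@@H](O)CC(=O)O4)cnc3c2Sc2cccc(OC)c2)c1` gives 74600 nM
- compound 3 `CC(C)c1ccc(Sc2cc3c(Sc4ccc(C(C)C)cc4)c(/C=C/[C@@H]4C[C@@H](O)CC(=O)O4)cnc3c(Sc3ccc(C(C)C)cc3)c2Sc2ccc(C(C)C)cc2)cc1` gives 4350 nM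

Compound 3 stands at the lowest number of the three in this assay; its gaps to compound 1 and to compound 2 both lie beyond the usual scatter, so it is the strongest inhibitor shown. Compound 4 `CC(C)c1ccc(Sc2cc3ncc(/C=C/[C@@H]4C[C@@H](O)CC(=O)O4)c(Sc4ccc(C(C)C)cc4)c3cc2Sc2ccc(C(C)C)cc2)cc1` differs from compound 3 in one place: hydrogen in place of (4-isopropylphenyl)sulfanyl on an aromatic carbon. For the measured compounds named here, no pair of measured compounds shows this change, so its effect is not known from the data. Given that compound 3 carries the lowest number yet, the step to compound 4 is expected to be small, most likely none beyond the scatter or a slight rise. Compound 4 is thus expected to give 6000 nM in this assay, within 1500 nM to 25000 nM, an expected step of a 1.4-fold higher number from compound 3 to compound 4 (0.14 log units; within the scatter).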

Compound 4, half-maximal inhibitory concentration: 14200 nM
Compound 4: middle estimate off by 2.4-fold (0.37 log units), on the low side, within the range that was stated.
By their numbers in this assay, from the lowest: compound 3; then compounds 1 and 4 (each within the scatter of the next); then compound 2.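

Hydrogen in place of (4-isopropylphenyl)sulfanyl on this aromatic carbon gives a 3.3-fold higher number from compound 3 to compound 4 (0.51 log units; beyond the scatter) in this assay, so inhibition in this pair is stronger with the group present, though the step is modest. For the compounds shown here, this is the only step that differs in one place, and the earlier compounds gave no reading of this position. Nothing at hand accounts for the size of the step.

Going by these compounds, it remains open whether an amine, a methoxy group or a chlorine on this carbon would hold the number of compound 3. On these data alone, it is also open whether the size of the sulfanyl substituent matters here.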